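The source may hold more compounds than are shown below. What is called first, only, known or untested is meant among the compounds shown, and "the series" means these compounds.

Of the compounds shown here, three have been measured in a functional assay on EL4 cells (Mus musculus) for inhibition, tested at 100 uM; a higher number here means more inhibition at the concentration tested (going by the name of the read-out), a lower number less inhibition.
Compound 1, `OC[C@H]1OC(n2cnc3c(Nc4ccccc4)nccc32)[C@H](O)[C@@H]1O`, gives 10% in this assay.
Compound 2, `OCCNc1[nH]ccc2ncnc1-2`, is reported only at a limit of the assay, < 5%.
Compound 3, `OC[C@H]1OC(n2cnc3c(S)nccc32)[C@H](O)[C@@H]1O`, is likewise reported only at a limit of the assay, < 5%.

Compound 3 therefore stands at the floor of what this assay reports: its value is a limit, not a number, and it is the limit of < 5% in this assay, at which 2 of the 3 values shown sit. Among the compounds with values here, the single measured step that arrives at compound 3 is a number at least 5 percentage points lower from compound 1 to compound 3 (that floor lies within the scatter), a change whose size cannot be told apart from the scatter. Compound 4, `OCCNc1nccc2c1ncn2C1O[C@H](CO)[C@@H](O)[C@H]1O`, differs from compound 3 in one place: (2-hydroxyethyl)amino in place of sulfanyl on an aromatic carbon. The same (2-hydroxyethyl)amino group is carried by compound 2 on a smaller core, and compound 2 too is reported only at a limit. No measured step tests the exchange of sulfanyl for (2-hydroxyethyl)amino directly, and the one step shown lies within the scatter. For compound 4 a step no larger than the scatter is therefore expected, a number no lower from compound 3 to compound 4 (the limit leaves the size open). Compound 4 is estimated to give 5% in this assay, within a range from 0% to 15%.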

Compound 4, a percentage reported as inhibition, at one concentration (the size of the read-out at that concentration, not a potency): 6%
Beside the measured number, compound 4's estimate is 1 percentage points below it; the range from low to high includes it.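

With compound 4, this aromatic carbon on the shared core has now carried anilino, sulfanyl and (2-hydroxyethyl)amino in this assay, and the exchange of sulfanyl for (2-hydroxyethyl)amino gives a number at least 1 percentage points higher from compound 3 to compound 4 (that floor lies within the scatter). Compound 3 is reported at a limit, so that step has a floor and no exact size: the limit of < 5% in this assay, at which 2 of the 4 values shown sit. Changing phenyl to 2-hydroxyethyl on the nitrogen gives a number 4 percentage points lower from compound 1 to compound 4 (within the scatter), so the anilino and (2-hydroxyethyl)amino groups cannot be told apart at the concentration tested, and neither step separates the groups at this position.

From the compounds shown here alone, whether any group on this carbon can raise inhibition beyond the scatter remains open. A simple amino group, a longer chain ending in a carboxylic acid, or a benzylamino group in the same place would each put that question to a different kind of substituent.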